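The source may report more compounds than this note shows. Statements on the series, on what has been measured and on what is new or still open speak of the compounds shown alone.

Measured so far in a functional assay on A549 cells (Homo sapiens) for antiproliferative activity, read by MTT assay; a higher number here means a weaker inhibitor, a lower number a stronger inhibitor:
- compound 1 `COc1cc2c(Oc3ccc(NC(=O)Nc4ccc(C(F)(F)F)cc4Cl)cc3)ccnc2cc1OCCCCCCC(=O)NO` gives 970 nM
- compound 2 `COc1cc2c(Oc3ccc(NC(=O)Nc4ccccc4F)cc3)ccnc2cc1OCCCCCCC(=O)NO` gives 870 nM
- compound 3 `COc1cc2c(Oc3ccc(NC(=O)Nc4ccc(Cl)c(C(F)(F)F)c4)cc3)ccnc2cc1OCCCCCCC(=O)NO` gives 5020 nM

Compound 3 has the highest number of the three, so it is the weakest inhibitor here. Compound 4 `COc1cc2c(Oc3ccc(NC(=O)N/N=C/c4ccccc4)cc3)ccnc2cc1OCCCCCCC(=O)NO` changes one group: a group of 8 heavy atoms (7 carbon, 1 nitrogen; one six-membered aromatic ring of carbon only) in place of a group of 11 heavy atoms (7 carbon, 3 fluorine, 1 chlorine; one six-membered aromatic ring of carbon only), on an amide-type nitrogen. For the measured compounds named here, two measured steps bear on this, a 5.2-fold higher number from compound 1 to compound 3 (0.71 log units; beyond the scatter) and a 5.8-fold higher number from compound 2 to compound 3 (0.76 log units; beyond the scatter), and both are modest but beyond the scatter. Both involve gaining the group that compound 4 loses. The remaining step, a 1.1-fold lower number from compound 1 to compound 2 (0.05 log units; within the scatter), lies within the scatter. Going by the values given here, no measured compound carries the entering group, so a modest move to a lower number in this assay is expected, with wide uncertainty. The expected step is a 3.1-fold lower number from compound 3 to compound 4 (0.50 log units; beyond the scatter). The estimated value for compound 4 is 1600 nM, with an expected range of 450 nM to 5500 nM.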

Compound 4, half-maximal inhibitory concentration: 3700 nM
Beside the measured number, compound 4's estimate is 2.3-fold (0.36 log units) below it; measured number inside the range.
By their numbers in this assay, from the lowest: compounds 2 and 1 (each within the scatter of the next); then compounds 4 and 3 (each within the scatter of the next).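

In this assay, replacing the 4-chloro-3-(trifluoromethyl)phenyl on this amide-type nitrogen with a group holding a double bond outside its aromatic ring gives a 1.4-fold lower number from compound 3 to compound 4 (0.13 log units; within the scatter), so the two groups cannot be told apart here. The new group still falls short of the two other aryl groups, with a 4.3-fold higher number from compound 2 to compound 4 (0.63 log units; beyond the scatter) and a 3.8-fold higher number from compound 1 to compound 4 (0.58 log units; beyond the scatter), both beyond the scatter. No measurement shown here explains these numbers.

As far as these compounds go, it remains open how a chlorine on the aromatic ring of the new group would shift its number. Also open, from the compounds shown here alone, is how an amine or a carboxylic acid would fare on this nitrogen.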